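The source may hold more compounds than are shown below. What is called first, only, known or untested is meant among the compounds shown, and "the series" means these compounds.

Working notes on the series. Compound 1 `Cc1cc(NC(=O)CN2CCC(c3cccc[n+]3[O-])CC2)ccc1F`, compound 2 `O=C(CN1CCC(c2cccc[n+]2[O-])CC1)Nc1ccc(F)cc1F` and compound 3 `O=C(CN1CCC(c2cccc[n+]2[O-])CC1)Nc1cccc(-c2ccccc2)c1` share one core; compound 4 `CSc1cccc(NC(=O)CN2CCC(c3cccc[n+]3[O-])CC2)c1` has not yet been measured. In a functional assay on HEK293 cells for agonist activity at D(4) dopamine receptor (Homo sapiens), read by FLIPR (a higher number here means a larger maximal response, a lower number a smaller maximal response), compound 1 gives 75%, compound 2 gives 74% and compound 3 gives 75%. Within the data shown here, the only single-change step measured, a number 1 percentage points lower from compound 1 to compound 2 (within the scatter), stays within the scatter. Compound 3 stands level with compound 1 at the digits printed, and compound 2 differs from it only within the scatter.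

The change to compound 4 is methylsulfanyl in place of phenyl on an aromatic carbon. Among the measured compounds shown here, no measured step touches this exchange; the one step known concerns a different substitution of the same ring and was flat. The step of a number 3 percentage points lower from compound 3 to compound 4 (within the scatter) is therefore expected to stay within the scatter. Compound 4 is expected at 72%, in the range 55% to 85%.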

Compound 4, largest response reached (reported as efficacy), in percent of the reference or control that the assay uses: 56%
For compound 4 the middle estimate is 16 percentage points above the measured one; the measured number falls inside the stated range.
By their numbers in this assay, from the lowest: compound 4; then compounds 2, 1 and 3 (each within the scatter of the next).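

In this assay methylsulfanyl in place of phenyl on this aromatic carbon gives a number 19 percentage points lower from compound 3 to compound 4 (beyond the scatter) and so shows that the response at this position depends on the group it carries. The two exchanges of the whole aryl group read the same way, with a number 18 percentage points lower from compound 2 to compound 4 (beyond the scatter) and a number 19 percentage points lower from compound 1 to compound 4 (beyond the scatter) set against the earlier flat step. No measured evidence bears on the reason for this drop.

The compounds shown leave open whether the loss of the phenyl ring or the arrival of the sulfur carries the difference. As far as these compounds go, how a methoxy group or an amine on the same aromatic carbon would read also stays open.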